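The compounds below may be only part of what the source reports. "The series", "measured", "known", "first", "only" and "open" are said of these compounds alone.

Measured compounds:
compound 1, `Cc1cc(C(=O)N[C@@H](CC(=O)NCC(C)(C)C)C(=O)N[C@@H](CCc2ccccc2)C(=O)NCc2ccccc2Cl)no1`: 9 nM
compound 2, `C[C@H](NC(=O)[C@H](CC(=O)NCC(C)(C)C)NC(=O)CCc1ccccc1)C(=O)NCc1ccccc1Cl`: 10 nM

In an assay on HEK293 cells for inhibition of nuclear factor NF-kappa-B complex (Homo sapiens), read by a luciferase reporter, with stated times of 1 h and 3 h (a lower number here means a stronger inhibitor, a higher number a weaker inhibitor), compound 2 gives 10 nM, the higher of the two numbers. Compound 1 gives 9 nM, which lies within the scatter of compound 2. Compound 3, `Cc1cc(C(=O)N[C@@H](CC(=O)NCC(C)(C)C)C(=O)N[C@@H](C)C(=O)NCc2ccccc2Cl)no1`, is not yet measured. Against compound 2 the change is 5-methyl-1,2-oxazol-3-yl in place of phenethyl on a carbonyl carbon. Among the measured compounds shown here, no step between measured compounds isolates this change; the same carbonyl-bound 5-methyl-1,2-oxazol-3-yl is carried by compound 1, whose number sits within the scatter of compound 2, so no move beyond the scatter is expected in either direction. Compound 3 is estimated at 12 nM, range 4 nM to 40 nM. The expected step is a 1.2-fold higher number from compound 2 to compound 3 (0.08 log units; within the scatter).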

Compound 3, half-maximal inhibitory concentration: 120 nM
Estimate against measurement, compound 3: 10-fold (1.00 log units) below; measured number above the stated range.
By their numbers in this assay, from the lowest: compounds 1 and 2 (each within the scatter of the next); then compound 3.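

In this assay, 5-methyl-1,2-oxazol-3-yl in place of phenethyl on a carbonyl carbon gives a 12-fold higher number from compound 2 to compound 3 (1.08 log units; beyond the scatter), so the two groups are not interchangeable at this position in this pair. Hydrogen in place of benzyl on a saturated chain carbon gives a 13-fold higher number from compound 1 to compound 3 (1.12 log units; beyond the scatter), so 5-methyl-1,2-oxazol-3-yl on the carbonyl carbon holds a low number only in the presence of that benzyl. Nothing measured here explains either step. On these data alone, whether a plain benzyl or a longer alkyl chain on this carbonyl carbon would keep the number of compound 2 remains open.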